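This account rests on a few compounds, and the source may have more. Where it says the series, first, only, none or still open, it means among the compounds named here.

Compound 2 `C=C(Br)C(=O)Nc1cccc(-c2cn3nc(-c4cccc(OC)c4)sc3n2)c1` and compound 1 `C=C(Br)C(=O)Nc1cccc(-c2cn3nc(-c4ccc(OCC)cc4)sc3n2)c1` share one core and differ only in the aryl group on it. In a functional assay on CCRF-CEM cells (Homo sapiens) for inhibition, read by cell counting, with a stated time of 3 days (a lower number here means a stronger inhibitor, a higher number a weaker inhibitor), compound 1 gives 1400 nM, and compound 2 gives 1200 nM. Among the compounds with values here, the single measured step, a 1.2-fold lower number from compound 1 to compound 2 (0.07 log units; within the scatter), shows that exchanging 4-ethoxyphenyl for 3-methoxyphenyl leaves the number essentially unchanged. Compound 2 therefore stands at the lower of the two numbers, but its separation from compound 1 lies within the scatter, so no order between them can be claimed.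

Compound 3 `C=C(Br)C(=O)Nc1cccc(-c2cn3nc(-c4cccs4)sc3n2)c1` carries the next change at the same position: thiophen-2-yl in place of 3-methoxyphenyl on an aromatic carbon. Within the data shown here, no measured step here covers a five-membered heteroaryl in place of a phenyl, so the only guidance is that the one aryl-to-aryl exchange in this set, from compound 1 to compound 2, stayed within the scatter. On that basis the step of a 1.1-fold higher number from compound 2 to compound 3 (0.03 log units; within the scatter) is expected to be small, without a clear direction. Compound 3 is thus estimated at 1300 nM in this assay, with a range from 450 nM to 4000 nM.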

Compound 3, half-maximal inhibitory concentration: 410 nM
For compound 3 the middle estimate is 3.2-fold (0.50 log units) above the measured one, outside the stated range (below it).
By their numbers in this assay, from the lowest: compound 3; then compounds 2 and 1 (each within the scatter of the next).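

Thiophen-2-yl is the first group at this position to move the number beyond the scatter in this assay: it gives a 2.9-fold lower number from compound 2 to compound 3 (0.47 log units; beyond the scatter) and a 3.4-fold lower number from compound 1 to compound 3 (0.53 log units; beyond the scatter), whereas the exchange between the two alkoxy-bearing phenyl groups gave only a 1.2-fold lower number from compound 1 to compound 2 (0.07 log units; within the scatter). The position on the five-membered aromatic ring with 2 nitrogen and 1 sulfur is therefore not indifferent to the aryl group it carries, though both steps are modest. Each step replaces a six-membered aromatic ring of carbon only and its ether oxygen with a smaller five-membered aromatic ring with 1 hetero atom, so several differences change at once, and no measurement here accounts for the lower number.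

The compounds shown do not separate the contributions of ring size, the ring sulfur and the loss of the methoxy or ethoxy group, a question that unsubstituted phenyl, furan-2-yl or thiophen-3-yl would help to settle. Also open, from the compounds shown here alone, is how the number responds to a further group on the thiophen-2-yl ring, such as a methyl, a chlorine or an amine.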